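From benzyl to anilino on compound 1

This account rests on a few compounds, and the source may have more. Where it says the series, first, only, none or still open, it means among the compounds named here.

Two compounds have so far been measured in an ADME assay on a cell-free system (plasma, Rattus norvegicus) for metabolic stability, read by HPLC, with a stated time of 30 min, tested at 10 uM; a higher number here means that more of the compound is left, a lower number that less of the compound is left:

- compound 1 (`O=C(Oc1ccc(OCc2ccccc2)cc1)N(Cc1ccccc1)S(=O)(=O)c1ccc(Cl)cc1`) gives 2.1%
- compound 2 (`O=C(Nc1ccc(OCCCCc2ccccc2)cc1)N(Cc1ccccc1)S(=O)(=O)c1ccc(Cl)cc1`) gives 1.3%

Compound 1 stands level with compound 2, as their two numbers lie within the usual scatter of each other. Little of either compound is left at the end of this assay. Within the data shown here, the two differ in more than one place, so they offer no measured step for any single change.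

The next compound is compound 3 (`O=C(Oc1ccc(OCc2ccccc2)cc1)N(Nc1ccccc1)S(=O)(=O)c1ccc(Cl)cc1`), which keeps the core of compound 1 but carries anilino in place of benzyl on an amide-type nitrogen. Among the measured compounds shown here, nothing measured so far shows how this exchange plays out in this assay. The expectation therefore rests only on compound 1 (2.1%) and compound 2 (1.3%), and both of them leave little. No step beyond the scatter is expected, and any larger move would have to be upward. The estimated step is a number 1.9 percentage points higher from compound 1 to compound 3 (within the scatter) in size. For compound 3 the expected value is 4% (estimated range 0.5% to 25%).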

Compound 3, percent of the compound remaining: < 1%
Compound 3: a limit, no number (the forecaster's own chance of this, stated with the estimate: 5%); middle value at least 3 percentage points away from the limit.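

In this assay compound 3 gives < 1%, which is a limit of the assay and not a number. Among these compounds, this supplies the first measured step at the amide-type nitrogen whose other neighbours are the carbonyl carbon and the sulfonyl sulfur, a number at least 1.1 percentage points lower from compound 1 to compound 3 (that floor lies within the scatter), and it shows that anilino in place of benzyl, with its added hydrogen-bond donor and acceptor, does not leave a readable amount of the compound at the end of the assay. The true size of this step cannot be read, and the change cannot be separated from the scatter, because the value of compound 3 rests on an assay limit: the limit of < 1% in this assay, at which 1 of the 3 values shown sits.

The compounds shown leave open whether a methyl group, a longer alkyl chain or a chain ending in a carboxylic acid on this same nitrogen would leave more of the compound in this assay. They also leave open what the benzyl and anilino groups each contribute when the shared core is otherwise changed, since compound 2 differs from compound 1 in more than one place.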